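Swapping the Naphthyl Ether for a Tetrafluorophenyl Ether

The source may hold more compounds than are shown below. What is called first, only, known or untested is meant among the compounds shown, and "the series" means these compounds.

Compound 1: `CC(C)[C@H](NC(=O)COc1cccc2ccccc12)C(=O)N[C@@H](CC(=O)O)C(=O)COc1cccc2ccccc12`, 19000 nM
Compound 2: `CC(C)[C@H](NC(=O)COc1cccc2ccccc12)C(=O)N[C@@H](CC(=O)O)C(=O)COc1ccc2ccccc2c1`, 15900 nM

In a functional assay with Homo sapiens as the target (on this read-out lower numbers stand for stronger inhibition and higher numbers for weaker inhibition), compound 1 stands highest of the two numbers, and its nearest neighbour is compound 2, with a 1.2-fold lower number from compound 1 to compound 2 (0.08 log units; within the scatter). Compound 3 `CC(C)[C@H](NC(=O)COc1cccc2ccccc12)C(=O)N[C@@H](CC(=O)O)C(=O)COc1c(F)c(F)cc(F)c1F` is unmeasured and differs from compound 1 by 2,3,5,6-tetrafluorophenyl in place of naphthalen-1-yl on an oxygen on a saturated carbon. Among the compounds with values here, the single measured step only exchanges one naphthalenyl for another at the same oxygen and stays within the scatter, so there is no direct guide for a fluorinated phenyl here. Compound 3 is therefore expected to show a 1.1-fold higher number from compound 1 to compound 3 (0.02 log units; within the scatter), a step not clearly beyond the scatter. Compound 3 is estimated at 20000 nM, between 6000 nM and 60000 nM.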

Compound 3, half-maximal inhibitory concentration: 6250 nM
Compound 3: the middle estimate sits 3.2-fold (0.51 log units) above what was measured; the range from low to high includes it.
By their numbers in this assay, from the lowest: compound 3; then compounds 2 and 1 (each within the scatter of the next).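

In this assay, within the data shown here, the exchange of one naphthalenyl for the other had stayed within the scatter, but 2,3,5,6-tetrafluorophenyl on this oxygen gives the first steps beyond it (a 3.0-fold lower number from compound 1 to compound 3 (0.48 log units; beyond the scatter)) and (a 2.5-fold lower number from compound 2 to compound 3 (0.41 log units; beyond the scatter)). The position on this oxygen thus tolerates a single fluorinated ring in place of the two-ring naphthalenyl, and the number improves modestly. Nothing measured here explains the change. The compounds shown leave open whether the four fluorine atoms or the loss of the second ring accounts for these steps. A plain phenyl at this oxygen would separate the two.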